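A few compounds are considered here, and "the series" means these few. Any claim that something is new, unique, unknown or untested is made for them only; others in the source may bear on it.

Measured compounds:
compound 1 `O=Cc1c(-c2ccccc2)sc2ccccc12` with 51% in a functional assay on MCF7 cells (Homo sapiens) for cytotoxicity, tested at 10 uM; on this read-out higher numbers stand for more inhibition at the one concentration tested (going by the name of the read-out) and lower numbers for less inhibition
compound 2 `O=Cc1c(-c2ccc(C(F)(F)F)cc2)sc2ccccc12` with 73%
compound 3 `N#Cc1ccccc1-c1sc2ccccc2c1C=O` with 38%

Compound 1 stands second highest of the three numbers: compound 3 sits nearest, a number 13 percentage points lower from compound 1 to compound 3 (beyond the scatter), and compound 2 furthest, a number 22 percentage points higher from compound 1 to compound 2 (beyond the scatter). The unmeasured compound 4 `N#Cc1c(-c2ccccc2)sc2ccccc12` differs from compound 1 at the core, not at the attached phenyl ring: cyano in place of formyl on an aromatic carbon. Neither measured step bears on this change. For the measured compounds named here, both steps alter the phenyl ring of compound 1, the trifluoromethyl step raising the number and the cyano step lowering it; no compound in the set has the formyl on the core replaced. The measured cyano step of compound 3 concerns a different position, so it gives no direct guide. Absent any comparable step, a number close to that of compound 1 is expected for compound 4, a number 6 percentage points lower from compound 1 to compound 4 (within the scatter), with a wide range. Compound 4 is therefore estimated at 45%, between 20% and 70%.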

Compound 4, a percentage reported as inhibition, at one concentration (the size of the read-out at that concentration, not a potency): 51%
Compound 4: middle estimate off by 6 percentage points, on the low side; low and high end bracket the measured number.
By their numbers in this assay, from the lowest: compound 3; then compounds 1 and 4 (each within the scatter of the next); then compound 2.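

In this assay, cyano in place of formyl on the aromatic carbon of the five-membered ring gives no change at the digits printed from compound 1 to compound 4 (within the scatter). For the compounds shown here, the earlier compounds varied only the attached phenyl ring, so this is the first reading at this position, and it shows that, in this one comparison, the formyl can be exchanged for cyano without a change that stands out from the scatter. No measurement is available that would explain why the two groups read alike.

The compounds shown leave open how a carboxylic acid, an amine or a hydroxymethyl group on this carbon would read. They also leave open whether the rise seen with trifluoromethyl on the phenyl ring, a number 22 percentage points higher from compound 1 to compound 2 (beyond the scatter), or the fall seen with cyano there, a number 13 percentage points lower from compound 1 to compound 3 (beyond the scatter), would recur with cyano on the core.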